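A few compounds are considered here, and "the series" means these few. Any claim that something is new, unique, unknown or untested is made for them only; others in the source may bear on it.

Compounds measured in a functional assay on HepG2 cells (Homo sapiens) for antiproliferative activity, read by MTT assay, with a stated time of 48 h (a higher number here means a weaker inhibitor, a lower number a stronger inhibitor), so far:

- compound 1 `CCCC(C)Oc1ccc(C(=O)/C=C/c2c(/C=C/c3ccc(OC)cc3)cc(OC)cc2OC)cc1` gives 11.1 ug/mL
- compound 2 `CCCCCCOc1ccc(C(=O)/C=C/c2c(/C=C/c3ccc(OC)cc3)cc(OC)cc2OC)cc1` gives 16.2 ug/mL

Compound 1 has a single measured neighbour and cannot be told apart from it, with a 1.5-fold higher number from compound 1 to compound 2 (0.16 log units; within the scatter) as the whole of the spread. Compound 3 `COc1ccc(/C=C/c2cc(OC)cc(OC)c2/C=C/C(=O)c2cccc(Cl)c2)cc1` has not yet been measured. Its difference from compound 1 is 3-chlorophenyl in place of 4-(1-methylbutoxy)phenyl on a carbonyl carbon and amounts to 3-chlorophenyl in place of 4-(1-methylbutoxy)phenyl on a carbonyl carbon. Among the measured compounds shown here, the one measured step bears on this only weakly. It exchanges hexyl for 1-methylbutyl on an oxygen on an aromatic ring, so it alters only the chain that leaves in compound 3. For the measured compounds named here, no measured compound carries chlorine or lacks that chain, so the data give neither a size nor a direction for the whole exchange. The working expectation is therefore no change beyond the scatter, held with a wide margin on both sides. The step expected is a 1.1-fold higher number from compound 1 to compound 3 (0.03 log units; within the scatter) and remains a weakly supported estimate. In this assay compound 3 is estimated at 12 ug/mL with a range from 5 ug/mL to 28 ug/mL expected.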

Compound 3, half-maximal inhibitory concentration: 9.5 ug/mL
Compound 3: the middle estimate sits 1.3-fold (0.10 log units) above what was measured; low and high end bracket the measured number.
By their numbers in this assay, from the lowest: compounds 3, 1 and 2 (each within the scatter of the next).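

On the carbonyl carbon, this assay gives a 1.2-fold lower number from compound 1 to compound 3 (0.07 log units; within the scatter) for 3-chlorophenyl in place of 4-(1-methylbutoxy)phenyl. The earlier step only reshaped the chain on the oxygen, whereas this change removes the chain and that oxygen altogether and brings in chlorine, with a smaller group overall, yet compound 3 cannot be told apart from compound 1; among the compounds shown, then, a number of this size does not depend on keeping the 1-methylbutoxy chain at this place. Nothing is available that would account for this result or for the absence of a clear difference.

Since the chain and its oxygen leave as chlorine enters in a single exchange, the part each plays cannot be separated, and two changes that offset each other cannot be told from two that do nothing. A plain phenyl, a bromine or a methoxy group on that ring, or an amine or a carboxylic acid in place of the chlorine, would be needed to show whether this place tolerates any group or only ones like those seen here.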